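Removing the benzyl group from compound 2

This account rests on a few compounds, and the source may have more. Where it says the series, first, only, none or still open, it means among the compounds named here.

Compound 1 `COc1cc(OC)c2cc(-c3ccccc3)c(O)nc2c1` and compound 2 `COc1cc(OC)c2cc(-c3ccc(OCc4ccccc4)cc3)c(O)nc2c1` share one core, and both have been read in a functional assay on J82 cells (Homo sapiens) for cytotoxicity, read by colorimetric assay and MTT assay; on this read-out lower numbers stand for stronger inhibition and higher numbers for weaker inhibition. In this assay compound 1 gives 10000 nM. Compound 2 gives 10000 nM, which stands level with compound 1 at the digits available. Going by the values given here, the only measured step bears on the group in question: no change at the digits printed from compound 1 to compound 2 (within the scatter), with benzyloxy in place of hydrogen on an aromatic carbon.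

Compound 3 `COc1cc(OC)c2cc(-c3ccc(O)cc3)c(O)nc2c1` is the next entry. The change is hydrogen in place of benzyl on an oxygen on an aromatic ring, or benzyloxy to hydroxy. Among the compounds with values here, the hydroxy group itself has no measured counterpart, so the evidence is thin. Within the data shown here, still, compound 2 at 10000 nM shows no separation from compound 1 at 10000 nM, and this is the sole guide. No step beyond the scatter is therefore expected in this assay, in either direction. The estimated step is no change at the digits printed from compound 2 to compound 3 (within the scatter). For compound 3 the expected value is 10000 nM, with an estimated range of 4000 nM to 20000 nM.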

Compound 3, half-maximal inhibitory concentration: 10000 nM
For compound 3 middle estimate and measured number coincide at the digits printed; low and high end bracket the measured number.
By their numbers in this assay, from the lowest: compounds 1, 2 and 3 (each within the scatter of the next).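

Notes on the aromatic position. In this assay, the swap of benzyl for hydrogen on an oxygen on an aromatic ring gives no change at the digits printed from compound 2 to compound 3 (within the scatter), so the hydroxy group now has a measured reading and the benzyl group is shown to be removable without a visible step. The comparison with the unsubstituted compound gives a second reading of the same place, no change at the digits printed from compound 1 to compound 3 (within the scatter), which means that hydrogen, benzyloxy and hydroxy on this aromatic carbon all stand level in this assay, and none of the three can be ranked above another. No measurement on hand gives a reason for this flat reading.

The three compounds therefore offer no contrast from which any link between this place and cytotoxicity on these cells could be drawn, and compound 3 at 10000 nM marks no progress or loss against the others. As far as these compounds go, whether a different group at this place, such as an amine, a carboxylic acid or a longer alkoxy chain, would move the reading away from this level stays open, as does the contribution of the two methoxy groups on the shared core.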